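Thiophen-3-yl in Place of 4-Fluorophenyl: an Expectation

The source may hold more compounds than are shown below. What is called first, only, known or untested is meant among the compounds shown, and "the series" means these compounds.

Compound 1 `CC(O)c1cn([C@@H]2O[C@H](CO)[C@@H](O)[C@H]2O)nn1`: in a functional assay on CCRF-CEM cells (Homo sapiens) (a higher number here means a weaker inhibitor, a lower number a stronger inhibitor), compound 1 gives only a limit, > 200000 nM.
Compound 2 `OC[C@H]1O[C@@H](n2cc(-c3ccccn3)nn2)[C@H](O)[C@@H]1O`: in this assay compound 2 gives 245000 nM.
Compound 3 `OC[C@H]1O[C@@H](n2cc(-c3ccc(F)cc3)nn2)[C@H](O)[C@@H]1O`: in this assay compound 3 gives 217000 nM.

Compound 3 holds the lowest of the two numbers, yet the step of a 1.1-fold lower number from compound 2 to compound 3 (0.05 log units; within the scatter) sits within the scatter. The steps a step that the limit leaves unreadable from compound 1 to compound 2 and a step that the limit leaves unreadable from compound 1 to compound 3 cannot be read, because of the limit of > 200000 nM in this assay, at which 1 of the 3 values shown sits. Compound 4 `OC[C@H]1O[C@@H](n2cc(-c3ccsc3)nn2)[C@H](O)[C@@H]1O` differs from compound 3 in one place: thiophen-3-yl in place of 4-fluorophenyl on an aromatic carbon. Within the data shown here, the only readable step, from compound 2 to compound 3, exchanged one aromatic ring for another without a shift beyond the scatter, so a further ring swap is expected to give none either, a 1.0-fold higher number from compound 3 to compound 4 (0.01 log units; within the scatter). Compound 4 is therefore estimated at 220000 nM, between 100000 nM and 450000 nM.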

Compound 4, half-maximal inhibitory concentration: 139000 nM
Compound 4: the middle estimate sits 1.6-fold (0.20 log units) above what was measured; low and high end bracket the measured number.
By their numbers in this assay, from the lowest: compounds 4, 3 and 2 (each within the scatter of the next).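

In this assay, the five-membered thiophen-3-yl ring replaces either six-membered ring with no shift beyond the scatter: a 1.6-fold lower number from compound 3 to compound 4 (0.19 log units; within the scatter) and a 1.8-fold lower number from compound 2 to compound 4 (0.25 log units; within the scatter). This position has now carried three different aromatic rings, one of them holding sulfur, and their numbers remain within the scatter of each other. Against 1-hydroxyethyl only a floor can be read, an at least 1.4-fold lower number from compound 1 to compound 4 (0.15 log units; that floor lies within the scatter), and the steps to compound 2 and compound 3 cannot be read, because compound 1 stands at a limit: the limit of > 200000 nM in this assay, at which 1 of the 4 values shown sits.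

As far as these compounds go, whether an amine, a carboxylic acid or a longer carbon chain at this position would move the number beyond the scatter remains open.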